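Thiocarbonyl series: from compound 3 to compound 4

The source may report more compounds than this note shows. Statements on the series, on what has been measured and on what is new or still open speak of the compounds shown alone.

Compound 1 `COc1ccc(CN(C(=O)CSc2nc3ccccc3o2)c2cc(OC)c(OC)c(OC)c2)cc1`: 3280 nM
Compound 2 `COc1ccc(CN(C(=O)CSC(=S)N2CCOCC2)c2cc(OC)c(OC)c(OC)c2)cc1`: 4130 nM
Compound 3 `COc1ccc(CN(C(=O)CSC(=S)N2CCc3cc(Br)ccc32)c2cc(OC)c(OC)c(OC)c2)cc1`: 8060 nM

In a functional assay on HCT-116 cells (Homo sapiens) for inhibition, read by CCK-8 assay, with a stated time of 48 h (on this read-out higher numbers stand for weaker inhibition and lower numbers for stronger inhibition), compound 3 gives 8060 nM, and the whole series spans only a 2.5-fold higher number from compound 1 to compound 3 (0.39 log units; beyond the scatter). Compound 4 `COc1ccc(CN(C(=O)CSC(=S)N2CCc3ccccc3C2)c2cc(OC)c(OC)c(OC)c2)cc1` carries this change: 1,2,3,4-tetrahydroisoquinolin-2-yl in place of 5-bromo-2,3-dihydro-1H-indol-1-yl on a thiocarbonyl carbon. Among the measured compounds shown here, no measured step isolates it. For the measured compounds named here, the closest evidence is a 2.0-fold higher number from compound 2 to compound 3 (0.29 log units; within the scatter), the only measured exchange of the group on the thiocarbonyl carbon. A wider exchange of the group on sulfur gave a 1.3-fold higher number from compound 1 to compound 2 (0.10 log units; within the scatter). No step beyond the scatter is therefore expected in this assay, with perhaps a slight drift toward lower numbers. The expected change is a 1.7-fold lower number from compound 3 to compound 4 (0.23 log units; within the scatter). For compound 4 the estimate is 4800 nM, with an expected range of 1800 nM to 11000 nM.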

Compound 4, half-maximal inhibitory concentration: 15900 nM
The estimate for compound 4 lay 3.3-fold (0.52 log units) below the measured number; measured number above the stated range.
By their numbers in this assay, from the lowest: compounds 1, 2, 3 and 4 (each within the scatter of the next, the first and the last beyond it).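

In this assay the group on the thiocarbonyl carbon now shows a step beyond the scatter: 1,2,3,4-tetrahydroisoquinolin-2-yl in place of morpholin-4-yl gives a 3.8-fold higher number from compound 2 to compound 4 (0.59 log units; beyond the scatter), whereas its exchange for 5-bromo-2,3-dihydro-1H-indol-1-yl stays within the scatter at a 2.0-fold higher number from compound 3 to compound 4 (0.30 log units; within the scatter). The larger exchange on sulfur widens the span of the series to a 4.8-fold higher number from compound 1 to compound 4 (0.69 log units; beyond the scatter). Nothing measured here accounts for these shifts. The step from compound 3 to compound 4 changes the ring and removes the bromine together, so neither can be read alone. The unsubstituted 2,3-dihydro-1H-indol-1-yl or a piperazin-1-yl on the thiocarbonyl carbon would test this position further.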